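Compound 1 to compound 4: losing the trifluoromethyl

The source may report more compounds than this note shows. Statements on the series, on what has been measured and on what is new or still open speak of the compounds shown alone.

For the measured compounds named here, in a functional assay on CAL-51 cells (Homo sapiens) for antiproliferative activity, read by luminescence and CellTiter-Glo, with a stated time of 3 days (on this read-out higher numbers stand for weaker inhibition and lower numbers for stronger inhibition), compound 1 `C[C@@H](Oc1cc(C(=O)N(C)C)ccc1Nc1nc(O[C@H]2CC[C@@](C)(O)CC2)c2cc[nH]c2n1)C(F)(F)F` gives 24 nM, the second highest of the three numbers measured so far. Compound 2 `C[C@@H](Oc1cc(C(=O)N(C)C)ccc1Nc1nc(O[C@H]2CC[C@@](C)(O)CC2)c2c(Cl)c[nH]c2n1)C(F)(F)F` gives 10 nM, and compound 3 `COc1cc(N2CCC(C)(O)CC2)ccc1Nc1nc(O[C@H]2CCOC(C)(C)C2)c2cc[nH]c2n1` gives 71 nM.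

Compound 4 `CCOc1cc(C(=O)N(C)C)ccc1Nc1nc(O[C@H]2CC[C@@](C)(O)CC2)c2cc[nH]c2n1` has not yet been measured. It carries hydrogen in place of trifluoromethyl on a saturated chain carbon bound to an oxygen on an aromatic ring and a saturated chain carbon, so that 1-(trifluoromethyl)ethoxy becomes ethoxy (hydrogen in place of trifluoromethyl on a saturated chain carbon bound to an oxygen on an aromatic ring and a saturated chain carbon).

Going by the values given here, no measured pair isolates this change. Among the compounds with values here, the only measured step, a 2.4-fold lower number from compound 1 to compound 2 (0.38 log units; beyond the scatter), is chloro in place of hydrogen on an aromatic carbon. It is a different change in a different place, so it offers only a rough guide to how far a single change can move the numbers in this series. On that thin evidence, a modest move towards a higher number is expected in this assay, though the direction is a judgement and not a measured trend. The expected step is a 1.9-fold higher number from compound 1 to compound 4 (0.27 log units; within the scatter), which would not stand clearly beyond the scatter. Compound 4 is estimated at 45 nM, with an expected range of 15 nM to 130 nM.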

Compound 4, half-maximal inhibitory concentration: 26 nM
For compound 4 the middle estimate is 1.7-fold (0.24 log units) above the measured one; the measured number falls inside the stated range.
By their numbers in this assay, from the lowest: compound 2; then compounds 1 and 4 (each within the scatter of the next); then compound 3.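

With the ethoxy of compound 4 in place of the 1-(trifluoromethyl)ethoxy of compound 1, this assay gives a 1.1-fold higher number from compound 1 to compound 4 (0.03 log units; within the scatter) and so shows no difference that this read-out can resolve. For the compounds shown here, the earlier compounds offered only a step at an aromatic carbon, whereas this pair gives the first reading at this saturated chain carbon: here trifluoromethyl, with its 4 heavy atoms and no ring, can give way to hydrogen with the number staying within the scatter, a statement that rests on this single pair. No supporting data bear on this result, so the flat step stands as an observation without an explanation.

The compounds shown leave open whether the same exchange would read alike in the chloro-bearing compound 2, since one pair on the unchlorinated core does not settle that. They also leave open how far this position stretches, for instance whether a longer chain such as propoxy, a cyclopropyl ring or an amine on the chain would stay within the scatter of compound 1 or move clearly away from it.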